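A few compounds are considered here, and "the series" means these few. Any claim that something is new, unique, unknown or untested is made for them only; others in the source may bear on it.

Working notes on the series in an ADME assay on NIH3T3 cells (Mus musculus) for cytotoxicity, read by MTT assay, with a stated time of 24 h; on this read-out lower numbers stand for stronger inhibition and higher numbers for weaker inhibition. Compound 1 `O=C(CN1CCN(c2ccccc2)CC1)N1CCN(c2nnc(-c3ccccc3)c(-c3ccccc3)n2)CC1` gives only a limit, > 963000 nM. Compound 2 `O=C(CN1CCN(c2ccccc2Cl)CC1)N1CCN(c2nnc(-c3ccccc3)c(-c3ccccc3)n2)CC1` gives 350000 nM, and the step of an at least 2.7-fold lower number from compound 1 to compound 2 (0.43 log units; beyond the scatter) is at least modest. Compound 3 `Cc1ccc(-c2nnc(N3CCN(C(=O)CN4CCN(c5ccccc5)CC4)CC3)nc2-c2ccc(C)cc2)cc1` likewise gives only a limit, > 914000 nM, which is the limit of > 914000 nM in this assay, at which 1 of the 3 values shown sits. Compound 3 thus stands with compound 1 among the values that are limits rather than numbers. Compound 4 `Cc1ccc(-c2nnc(N3CCN(C(=O)CN4CCN(c5ccc([N+](=O)[O-])cc5)CC4)CC3)nc2-c2ccc(C)cc2)cc1` differs from compound 3 by nitro in place of hydrogen on an aromatic carbon. Among the compounds with values here, the one measured step that bears on this change, chloro entering on an aromatic carbon from compound 1 to compound 2, lowered the number; a downward step of similar size in this assay is therefore expected, though compound 3 starts at a limit. The expected step is an at least 1.8-fold lower number from compound 3 to compound 4 (0.26 log units; that floor lies within the scatter). Compound 4 is estimated at 500000 nM, within 150000 nM to 1500000 nM.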

Compound 4, half-maximal inhibitory concentration: > 844000 nM
Compound 4: no number, only a limit; the forecaster's own chance of this, stated with the estimate: 50%; middle value at least 1.6-fold (0.22 log units) from the limit.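

In this assay, within the data shown here, compound 3 and compound 4 both give only limits, so no step between them can be read. The compounds shown leave open whether nitro in place of hydrogen on an aromatic carbon changes the number at all.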